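Cytotoxicity survey of compounds 1 to 4

The source may hold more compounds than are shown below. What is called first, only, known or untested is meant among the compounds shown, and "the series" means these compounds.

Measured:
compound 1 `O=C1CSC(c2cccc(O)c2)N1CCN1CCCCC1` — 100%
compound 2 `O=C1CSC(c2ccc([N+](=O)[O-])cc2)N1CCN1CCCCC1` — 100%
compound 3 `COc1ccccc1C1SCC(=O)N1CCN1CCCCC1` — 100%

In an ADME assay on Vero cells (Chlorocebus sabaeus) for cytotoxicity, read by neutral red uptake, tested at 49 ug/mL (on this read-out lower numbers stand for a stronger effect and higher numbers for a weaker effect at the one concentration tested), compound 1 gives 100%. Compound 2 gives 100% and compound 3 gives 100%. Compound 1 thus stands level with both at the digits reported, compound 2 being its nearest neighbour and compound 3 its furthest, with neither gap exceeding the usual scatter. Among the measured compounds shown here, no step between measured compounds that differ in a single place is available, so no measured direction can be read from the series.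

Compound 4 `O=C1CSC(c2ccccc2Cl)N1CCN1CCCCC1` has not yet been measured in this assay. It differs from compound 1 in one place: 2-chlorophenyl in place of 3-hydroxyphenyl on a saturated ring carbon. Since every measured compound returns the same reading, the expected step of a number 2 percentage points lower from compound 1 to compound 4 (within the scatter) is none beyond the scatter. Compound 4 is therefore estimated at 98%, within a range from 85% to 100%.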

Compound 4, a percentage reported as activity, at one concentration (the size of the read-out at that concentration, not a potency): 100%
Compound 4: the middle estimate sits 2 percentage points below what was measured; the measured number falls inside the stated range.
By their numbers in this assay, from the lowest: compounds 1, 2, 3 and 4 (each within the scatter of the next).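

In this assay, 2-chlorophenyl in place of 3-hydroxyphenyl on the saturated ring carbon gives no change at the digits printed from compound 1 to compound 4 (within the scatter), so at this position the loss of the hydrogen-bond donor and acceptor of 3-hydroxyphenyl leaves the reading unmoved. Chloro in place of methoxy on an aromatic carbon gives no change at the digits printed from compound 3 to compound 4 (within the scatter), a second single-place change with no visible effect. No supporting measurement bears on this result. On these data alone, whether a carboxylic acid or an amine on the aromatic ring would move the reading remains open. So does the reading of these compounds at any other concentration.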